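Chloro substitution on the aryl ring across two cores

The source may hold more compounds than are shown below. What is called first, only, known or untested is meant among the compounds shown, and "the series" means these compounds.

Measured numbers so far come from an assay on cells for inhibition of Palmitoleoyl-protein carboxylesterase NOTUM variant C330S (Homo sapiens), read by fluorescence, with a stated time of 40 min; a lower number here means a stronger inhibitor, a higher number a weaker inhibitor:

compound 1 `O=C(O)C1CCN(c2ccccc2)C1` — 48000 nM
compound 2 `O=C(O)C1CCN(c2ccccc2Cl)C1` — 19000 nM
compound 3 `Cc1cc(C(=O)O)c(C)n1-c1ccc(Cl)cc1` — 860 nM

Going by the values given here, the one step between compounds that differ in a single place is a 2.5-fold lower number from compound 1 to compound 2 (0.40 log units; beyond the scatter), which goes with chloro in place of hydrogen on an aromatic carbon. Compound 3 gives the lowest of the three numbers, and both gaps to it are beyond the scatter; the difference between the core of compound 3 and the core of compound 1 is not broken down here.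

Compound 4 `Cc1cc(C(=O)O)c(C)n1-c1ccc(Cl)c(Cl)c1` has not yet been measured. It differs from compound 3 by chloro in place of hydrogen on an aromatic carbon. Among the compounds with values here, this is the same kind of change as the one from compound 1 to compound 2, not the same: in compound 2 the entering chloro sits ortho to a group of 8 heavy atoms, whereas in compound 4 it sits ortho to a chloro group (1 heavy atom) and meta to a large group. The change occurs twice among the compounds shown, so the expectation rests on the single earlier step of a 2.5-fold lower number from compound 1 to compound 2 (0.40 log units; beyond the scatter), which was modest and beyond the scatter, on a different core.

In this assay compound 4 is expected to give about 400 nM, with a likely range from 150 nM to 1100 nM. The estimate means a step of a 2.2-fold lower number from compound 3 to compound 4 (0.33 log units; beyond the scatter), expected to be of a size like the earlier one. A measured number within the scatter of compound 3 would still be consistent with this expectation.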

Compound 4, half-maximal inhibitory concentration: 270 nM
Compound 4: middle estimate off by 1.5-fold (0.17 log units), on the high side, and the stated range covers the measured number.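

In this assay, chloro in place of hydrogen on an aromatic carbon again goes with a lower number, as a 3.2-fold lower number from compound 3 to compound 4 (0.50 log units; beyond the scatter) shows, and this step on the core of compound 3 can be set directly against the earlier step on the core of compound 1: the same change on two cores in this assay, a 2.5-fold lower number (0.40 log units; beyond the scatter) from compound 1 to compound 2 and a 3.2-fold lower number (0.50 log units; beyond the scatter) from compound 3 to compound 4, 1.3-fold (0.10 log units) apart, within the scatter of two such steps

On these two cores, then, the size of the step carries over, even though in compound 4 the entering chloro sits ortho to a chloro group and meta to a large group. Going by these compounds alone, this does not show that the step would hold on any further core or at any other place on the aromatic ring, since it rests on only two pairs, and those pairs differ in both core and surroundings, so the two influences cannot be separated.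

The compounds shown leave open whether fluoro, methoxy or a nitrile on the same aromatic carbon of compound 4 would give a step of similar size. They also leave open how the numbers would move if an amide took the place of the carboxylic acid or if an ethyl group took the place of either methyl group on the core of compound 3.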